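This account rests on a few compounds, and the source may have more. Where it says the series, first, only, none or still open, it means among the compounds named here.

Of the compounds shown here, two with the same core have been measured in a functional assay on MOLT-4 cells (Homo sapiens) for antiproliferative activity; on this read-out lower numbers stand for stronger inhibition and higher numbers for weaker inhibition. There compound 1 `COc1ccc(-c2cc(N)c(C(=O)c3cc(OC)c(OC)c(OC)c3)s2)cc1OC` gives 20 nM, while compound 2 `COc1cc(C(=O)c2sc(-c3ccncc3)cc2N)cc(OC)c1OC` gives 88 nM, the higher of the two numbers. The next compound, compound 3 `COc1cc(C(=O)c2sc(-c3ccc(Cl)c(Cl)c3)cc2N)cc(OC)c1OC`, differs from compound 2 in one group: 3,4-dichlorophenyl in place of pyridin-4-yl on an aromatic carbon. Among the measured compounds shown here, only one measured step bears on this change, and it concerns the same place on the core. In that step, pyridin-4-yl took the place of 3,4-dimethoxyphenyl, giving a 4.4-fold higher number from compound 1 to compound 2 (0.64 log units; beyond the scatter), a modest change. Compound 3 again carries a six-membered aromatic ring of carbon only at this place, as compound 1 does, so that step, read backwards, is the guide. For the measured compounds named here, the chlorine atoms have no measured precedent here, and one step is thin evidence, so the expectation stays loose. A move towards a lower number, similar in size to the measured step or slightly smaller, is expected in this assay. The expected change is a 2.9-fold lower number from compound 2 to compound 3 (0.47 log units; beyond the scatter). For compound 3 the estimated value is 30 nM, with an expected range from 8 nM to 120 nM.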

Compound 3, half-maximal inhibitory concentration: 270 nM
The estimate for compound 3 lay 9.0-fold (0.95 log units) below the measured number, outside the stated range (above it).
By their numbers in this assay, from the lowest: compound 1; then compound 2; then compound 3.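

In this assay, a six-membered aromatic ring of carbon only at this place does not in itself give a lower number: 3,4-dichlorophenyl in place of pyridin-4-yl gives a 3.1-fold higher number from compound 2 to compound 3 (0.49 log units; beyond the scatter), so the direction of the earlier step did not carry over to this change. With the ring of carbon only kept and its two substituents changed, 3,4-dichlorophenyl in place of 3,4-dimethoxyphenyl gives a 14-fold higher number from compound 1 to compound 3 (1.13 log units; beyond the scatter), the largest step among these three compounds, which shows that the substituents on this ring can count for more here than the presence of a ring nitrogen. Nothing available on these compounds accounts for the difference between the chlorine and methoxy substituents.

The compounds shown leave open whether the two methoxy groups of compound 1 contribute together or singly, as a lone methoxy group or a lone chlorine on the same ring would show. They also leave open how a ring carrying an amine or a carboxylic acid would compare at this place on the shared core.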